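Chain extension on the quinoline-linked isoxazole, compound 3 to 4

This account rests on a few compounds, and the source may have more. Where it says the series, first, only, none or still open, it means among the compounds named here.

Measured so far:
- compound 1, `Cc1ccc(-c2cc(/C=N/c3ccccc3)on2)cc1`: 28900 nM
- compound 2, `FC(F)(F)c1ccc(-c2cc(/C=N/c3ccccc3)on2)cc1`: 41300 nM
- compound 3, `CCc1cc2ccccc2nc1-c1cc(-c2ccccc2)no1`: > 100000 nM

The read-out throughout is a functional assay on COLO 205 cells (Homo sapiens) for inhibition, read by MTT assay, with a stated time of 24 h; on this read-out higher numbers stand for weaker inhibition and lower numbers for stronger inhibition. For the measured compounds named here, compound 1 and compound 2 share one core and differ only in the aromatic substituent; the step of a 1.4-fold higher number from compound 1 to compound 2 (0.16 log units; within the scatter) is the only measured step in the set. Compound 3 has a different core, and its value of > 100000 nM is a limit of the assay and not a number. Compound 3 therefore stands at the weak end of what the assay can report.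

Compound 4, `CCCc1cc2ccccc2nc1-c1cc(-c2ccccc2)no1`, is obtained from compound 3 by methyl in place of hydrogen on a saturated chain carbon, two bonds along the chain from an aromatic carbon. Going by the values given here, no measured step bears on this kind of change: the step from compound 1 to compound 2 concerns a different core and a different position, so it gives no guide to size or direction here. With compound 3 already at the limit of > 100000 nM in this assay, at which 1 of the 3 values shown sits, the most that can be expected is that compound 4 also reports no number, and the step of a number no higher from compound 3 to compound 4 (the limit leaves the size open) is expected to be no change beyond the scatter. Compound 4 is expected at 100000 nM, with a range from 30000 nM to 300000 nM.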

Compound 4, half-maximal inhibitory concentration: 48900 nM
Compound 4: middle estimate off by 2.0-fold (0.31 log units), on the high side; the range from low to high includes it.
By their numbers in this assay, from the lowest: compounds 1, 2 and 4 (each within the scatter of the next). At a limit, above all of these: compound 3.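

In this assay, methyl in place of hydrogen on a saturated chain carbon, two bonds along the chain from an aromatic carbon, turns ethyl into propyl and gives an at least 2.0-fold lower number from compound 3 to compound 4 (0.31 log units; beyond the scatter). This place on the core of compound 3 therefore responds to a single added carbon, and this is the only step shown that lies beyond the scatter; the earlier trifluoromethyl for methyl step, on a different core, stayed within it. The size of the step remains open because the entry for compound 3 is a limit: the limit of > 100000 nM in this assay, at which 1 of the 4 values shown sits.

Going by these compounds, whether a longer chain such as butyl continues in the same direction, or how an amine or a carboxylic acid on this chain would read, stays open. With one step at this place, no trend with chain length can be stated.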